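A nitro group gives way to a propanoylamino group

A few compounds are considered here, and "the series" means these few. Any claim that something is new, unique, unknown or untested is made for them only; others in the source may bear on it.

Compound 1, `Cn1c(-c2ccc([N+](=O)[O-])cc2)nc2cc(C(F)(F)F)ccc21`: > 100000 nM
Compound 2, `O=C(CCl)Nc1ccc(-c2nc3cc(C(F)(F)F)ccc3[nH]2)cc1`: 22000 nM
Compound 3, `O=[N+]([O-])c1ccc(-c2nc3cc(C(F)(F)F)ccc3n2C2CCCCC2)cc1`: > 100000 nM

Of the compounds shown here, three have been measured in an ADME assay on BHK cells (Mesocricetus auratus) for cytotoxicity, read by MTT assay, with a stated time of 96 h; a lower number here means that less compound is tolerated, a higher number that more compound is tolerated. Compound 1 gives > 100000 nM; this is a limit of the assay, not a number. Compound 3 also gives only a limit, > 100000 nM. Compound 2 gives 22000 nM, a measured number. Compound 1 therefore stands at the limit of > 100000 nM in this assay, at which 2 of the 3 values shown sit. For the measured compounds named here, the single step between measured compounds that differ in one place, a step that the two limits leave unreadable from compound 1 to compound 3, has two limits at its ends, so its size cannot be read.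

Compound 4, `CCC(=O)Nc1ccc(-c2nc3cc(C(F)(F)F)ccc3n2C)cc1`, differs from compound 1 in one place: propanoylamino in place of nitro on an aromatic carbon. Going by the values given here, no measured step carries this change, so nothing measured bears directly on it, and compound 2 differs from compound 4 in more than one place, so its value shows only that a related compound reached a number below the limit. The step of an at least 1.2-fold lower number from compound 1 to compound 4 (0.09 log units; that floor lies within the scatter) is therefore an expectation anchored only to a limit. Compound 4 is expected to give about 80000 nM, in the range 25000 nM to 200000 nM.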

Compound 4, half-maximal cytotoxic concentration: > 100000 nM
Compound 4: only a limit was reported (the forecaster's own chance of this, stated with the estimate: 55%); at least 1.2-fold (0.09 log units) between middle value and limit.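

Compound 1 and compound 4 each give only a limit of the assay, so the step between them cannot be read: the limit of > 100000 nM in this assay, at which 3 of the 4 values shown sit.

The compounds shown leave open whether propanoylamino in place of nitro changes how much compound the cells tolerate.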